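The compounds below may be only part of what the source reports. "The series", "measured", "known", "first", "only" and "open" are said of these compounds alone.

Measured compounds:
compound 1, `Cc1ccc(-c2cc(-c3ccoc3)cc(-c3ccc(Cl)s3)n2)cc1`: 0%
compound 2, `Clc1cccc(-c2cc(-c3ccoc3)cc(-c3ccc(Cl)s3)n2)c1`: 2.1%
compound 3, `Cc1ccc(-c2cc(-c3ccc(Cl)o3)cc(-c3ccc(Cl)s3)n2)cc1`: 14.2%

Of the compounds shown here, three that share a core have been tested in an assay on isolated protein for inhibition of DNA topoisomerase 1 (Homo sapiens), with a stated time of 30 min, tested at 100 uM; a lower number here means less inhibition, a higher number more inhibition at the concentration tested (going by the name of the read-out). Compound 2 differs from compound 1 by 3-chlorophenyl in place of 4-methylphenyl on an aromatic carbon, and this step gives a number 2.1 percentage points higher from compound 1 to compound 2 (within the scatter), so the two values cannot be told apart. Compound 3 differs from compound 1 by 5-chlorofuran-2-yl in place of furan-3-yl on an aromatic carbon, and here the step is a number 14.2 percentage points higher from compound 1 to compound 3 (beyond the scatter). Among the three, compound 3 stands highest, beyond the scatter of both others.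

Compound 4, `Clc1cccc(-c2cc(-c3ccc(Cl)o3)cc(-c3ccc(Cl)s3)n2)c1`, has not yet been measured. It differs from compound 3 by 3-chlorophenyl in place of 4-methylphenyl on an aromatic carbon. The same kind of change has already been made once, from compound 1 to compound 2, though the surroundings are not identical: in that earlier pair the place was meta to a furan-3-yl group, whereas in compound 3 and compound 4 it is meta to a 5-chlorofuran-2-yl group. The cores of the two pairs differ as described for compound 1 and compound 3.

Because the earlier step was a number 2.1 percentage points higher from compound 1 to compound 2 (within the scatter), the corresponding step for compound 4 is expected to be small as well, estimated at a number 1.8 percentage points higher from compound 3 to compound 4 (within the scatter). Compound 4 is therefore expected to give about 16% in this assay, with a likely range from 6% to 27%.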

Compound 4, a percentage reported as inhibition, at one concentration (the size of the read-out at that concentration, not a potency): 13.3%
For compound 4 the middle estimate is 2.7 percentage points above the measured one; the range from low to high includes it.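

In this assay, 3-chlorophenyl in place of 4-methylphenyl gives a number 0.9 percentage points lower from compound 3 to compound 4 (within the scatter), and set beside its earlier use, this change carries over from one core to the other: the same change on two cores in this assay, a number 2.1 percentage points higher (within the scatter) from compound 1 to compound 2 and a number 0.9 percentage points lower (within the scatter) from compound 3 to compound 4, 3 percentage points apart, within the scatter of two such steps. The other change, 5-chlorofuran-2-yl in place of furan-3-yl, gives a number 11.2 percentage points higher from compound 2 to compound 4 (beyond the scatter), and this larger step also carries over: the same change on two cores in this assay, a number 14.2 percentage points higher (beyond the scatter) from compound 1 to compound 3 and a number 11.2 percentage points higher (beyond the scatter) from compound 2 to compound 4, 3 percentage points apart, within the scatter of two such steps. Within these four compounds, each change therefore looks much the same whichever group sits at the other place, but this does not show that either step would hold on a further core, and values at one concentration say nothing about potency.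

The compounds shown leave open whether the higher numbers go with the chlorine on the furan, with the way the furan is attached, or with both, as these two features change together in every pair. On these data alone, it also remains open what this assay would show with an amine or a carboxylic acid in place of the chlorine of 3-chlorophenyl, or with a plain furan-2-yl group in place of 5-chlorofuran-2-yl.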